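Aryl amide swap on a flavonol scaffold: nitrophenyl analogue

The source may report more compounds than this note shows. Statements on the series, on what has been measured and on what is new or still open speak of the compounds shown alone.

Of the compounds shown here, three sharing one core have been tested so far. Compound 1 `COc1cccc(C(=O)Nc2cccc(-c3oc4cc(-c5ccc(F)cc5)ccc4c(=O)c3O)c2)c1` gives 5650 nM in a functional assay on HeLa cells (Homo sapiens) for antiproliferative activity, read by CCK-8 assay, with a stated time of 72 h (a higher number here means a weaker inhibitor, a lower number a stronger inhibitor), compound 2 `CCc1ccc(C(=O)Nc2cccc(-c3oc4cc(-c5ccc(F)cc5)ccc4c(=O)c3O)c2)cc1` gives 21000 nM, and compound 3 `O=C(Nc1cccc(-c2oc3cc(-c4ccc(F)cc4)ccc3c(=O)c2O)c1)c1ccc(Cl)nc1` gives 4080 nM. Compound 3 sits at the low end of these numbers; compound 1 lies within the scatter of it, while compound 2 lies beyond, as the step of a 5.1-fold lower number from compound 2 to compound 3 (0.71 log units; beyond the scatter) shows, alongside the smaller step of a 1.4-fold lower number from compound 1 to compound 3 (0.14 log units; within the scatter).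

Compound 4 `O=C(Nc1cccc(-c2oc3cc(-c4ccc(F)cc4)ccc3c(=O)c2O)c1)c1ccc([N+](=O)[O-])cc1` has not yet been measured. It differs from compound 3 by 4-nitrophenyl in place of 6-chloropyridin-3-yl on a carbonyl carbon. Going by the values given here, the two measured steps at this same carbonyl carbon, a 1.4-fold lower number from compound 1 to compound 3 (0.14 log units; within the scatter) and a 5.1-fold lower number from compound 2 to compound 3 (0.71 log units; beyond the scatter), show that exchanging the aryl group on the amide moves this assay by only modest amounts, and neither of them involves a nitrophenyl group, so no direct precedent exists for this change. Compound 4 is therefore expected to land near compound 3, with an estimated step of a 1.2-fold higher number from compound 3 to compound 4 (0.09 log units; within the scatter). The estimate for compound 4 is 5000 nM, within a range from 1500 nM to 17000 nM.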

Compound 4, half-maximal inhibitory concentration: 12300 nM
Beside the measured number, compound 4's estimate is 2.5-fold (0.39 log units) below it, within the range that was stated.
By their numbers in this assay, from the lowest: compounds 3 and 1 (each within the scatter of the next); then compounds 4 and 2 (each within the scatter of the next).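

In this assay, the change on the carbonyl carbon gives a step beyond the scatter (a 3.0-fold higher number from compound 3 to compound 4 (0.48 log units; beyond the scatter)), so the 4-nitrophenyl amide does not match the 6-chloropyridin-3-yl amide. It also separates from the 3-methoxyphenyl amide (a 2.2-fold higher number from compound 1 to compound 4 (0.34 log units; beyond the scatter)), whereas nitro in place of ethyl on an aromatic carbon stays within the scatter (a 1.7-fold lower number from compound 2 to compound 4 (0.23 log units; within the scatter)); among these four compounds, therefore, the two 4-substituted phenyl amides sit together, apart from compounds 1 and 3. No measurement shown accounts for this grouping.

The compounds shown leave open whether the grouping holds for other groups on that phenyl ring, such as an amine or a carboxylic acid. They also do not show how an amide with a plain phenyl group would read in this assay.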